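A few compounds are considered here, and "the series" means these few. Any claim that something is new, unique, unknown or untested is made for them only; others in the source may bear on it.

Compound 1 `O=C(COc1ccc2c(=O)ccoc2c1)Nc1cccc(NC(=O)c2ccc(Br)cc2)c1` gives 303 nM in an assay on isolated protein for inhibition of Rho-associated protein kinase 1 (Homo sapiens), read by scintillation counting, radiometric assay and 33P incorporation, with a stated time of 40 min, in the presence of a further agent that is not named here; a higher number here means a weaker inhibitor, a lower number a stronger inhibitor.
Compound 2 `O=C(COc1ccc2c(=O)ccoc2c1)Nc1cccc(NC(=O)c2ccc(OC(F)(F)F)cc2)c1` gives 869 nM in this assay.

The two measured compounds share one core and differ only in the group attached to the carbonyl carbon whose other neighbour is the amide-type nitrogen. Compound 2 holds the higher of the two numbers: the step of a 2.9-fold higher number from compound 1 to compound 2 (0.46 log units; beyond the scatter) lies beyond the scatter, so compound 2 is the weaker inhibitor of this pair.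

Compound 3 `O=C(COc1ccc2c(=O)ccoc2c1)Nc1cccc(NC(=O)c2cccc([N+](=O)[O-])c2)c1` has not yet been measured. It differs from compound 2 in one place: 3-nitrophenyl in place of 4-(trifluoromethoxy)phenyl on a carbonyl carbon. Going by the values given here, only one measured step touches this part of the molecule, the exchange of bromo for trifluoromethoxy, which moved the number by a 2.9-fold higher number from compound 1 to compound 2 (0.46 log units; beyond the scatter). Neither measured compound carries a nitro group or a 3-nitrophenyl, so nothing measured shows directly what this change does.

The expectation therefore rests on thin ground: a number lying between those of compound 1 and compound 2 seems most plausible, so the expected step of a 1.7-fold lower number from compound 2 to compound 3 (0.24 log units; within the scatter) is small and within the scatter. Compound 3 is accordingly estimated at 500 nM, with a range from 150 nM to 1700 nM.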

Compound 3, half-maximal inhibitory concentration: 528 nM
Estimate against measurement, compound 3: 1.1-fold (0.02 log units) below; low and high end bracket the measured number.
By their numbers in this assay, from the lowest: compounds 1, 3 and 2 (each within the scatter of the next, the first and the last beyond it).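

Exchanging 4-(trifluoromethoxy)phenyl for 3-nitrophenyl on the carbonyl carbon gives a 1.6-fold lower number from compound 2 to compound 3 (0.22 log units; within the scatter), and exchanging 4-bromophenyl for the same group gives a 1.7-fold higher number from compound 1 to compound 3 (0.24 log units; within the scatter). In this assay, this position therefore takes a nitro-bearing ring, with its group named at a different ring number, and the result cannot be told apart from either earlier compound, even though compound 1 and compound 2 differ from each other beyond the scatter. Compound 3 thus adds a third kind of group at this position, but it does not show a clear gain or loss against either neighbour, and no supporting measurement is available to explain these numbers.

Since both the group and its ring number change together in compound 3, these compounds cannot separate the effect of the nitro group from the effect of where it sits, a question that a 4-nitrophenyl or a 3-bromophenyl group would address. Going by these compounds, it also remains open how this position would respond to a ring bearing an amine or a carboxylic acid, or to a plain unsubstituted phenyl.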